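Sulfonyl for Carbonyl: Cytotoxicity Outlook for Compound 4

The source may hold more compounds than are shown below. What is called first, only, known or untested is meant among the compounds shown, and "the series" means these compounds.

Measured in an ADME assay on Li23 cells (Homo sapiens) for cytotoxicity, read by WST assay; on this read-out lower numbers stand for higher toxicity in this test and higher numbers for lower toxicity in this test:
Compound 1, `Cc1cc(C(O)(C(F)(F)F)C(F)(F)F)ccc1N(C)C(=O)c1ccccc1`: compound 1 gives 9000 nM.
Compound 2, `Cc1ccc(C(=O)N(C)c2ccc(C(O)(C(F)(F)F)C(F)(F)F)cc2)cc1`: compound 2 gives 26000 nM.
Compound 3, `CN(C(=O)c1ccccc1)c1ccccc1C(O)(C(F)(F)F)C(F)(F)F`: compound 3 gives > 20000 nM, which is a limit of the assay rather than a number (the limit of > 20000 nM in this assay, at which 1 of the 3 values shown sits).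

Of the two numbers in hand, compound 2 carries the higher one; compound 1 sits at a lower number, and the gap between the two lies beyond the usual scatter. Compound 3 contributes only a limit and so cannot be ranked against either.

Compound 4, `CN(c1ccc(C(O)(C(F)(F)F)C(F)(F)F)cc1)S(=O)(=O)c1ccccc1`, has not yet been measured in this assay. It differs from compound 2 by phenylsulfonyl in place of (4-methylphenyl)carbonyl on a nitrogen on an aromatic ring. Among the compounds with values here, no measured pair in this set makes the same exchange, so the size of the step cannot be read from a comparable case. Within the data shown here, with compound 2 giving 26000 nM and compound 1 giving 9000 nM as the only numbers available, the expected step is a 1.3-fold lower number from compound 2 to compound 4 (0.11 log units; within the scatter), which is taken as small and of no certain direction beyond the scatter. Compound 4 is therefore estimated at 20000 nM, within a range from 7000 nM to 60000 nM.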

Compound 4, half-maximal cytotoxic concentration: 16000 nM
Compound 4: the middle estimate sits 1.3-fold (0.10 log units) above what was measured, within the range that was stated.
By their numbers in this assay, from the lowest: compounds 1, 4 and 2 (each within the scatter of the next, the first and the last beyond it).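

In this assay, within the data shown here, the exchange on a nitrogen on an aromatic ring gives the first step that can be read in this set: a 1.6-fold lower number from compound 2 to compound 4 (0.21 log units; within the scatter). Among these compounds, the result shows that this place accepts phenylsulfonyl in place of (4-methylphenyl)carbonyl without a shift beyond the scatter, even though the exchange replaces the carbonyl with a sulfonyl and removes the methyl from the aromatic ring in a single step, something that the earlier compounds, which offered no such pair, could not show. Among the compounds shown here, nothing measured here explains why the two groups give readings so close together, and the single step offers only a size, not a reason.

The compounds shown leave open how much of this small step belongs to the change from carbonyl to sulfonyl and how much to the methyl, since a (4-methylphenyl)sulfonyl group on the same nitrogen does not appear among them. They also leave open whether this tolerance would extend to a more different group at this place, such as an amine or a carboxylic acid on the phenyl of the phenylsulfonyl group, or a longer chain in place of the methyl on the nitrogen.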